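Chloro in Place of Trifluoromethyl on an Aromatic Carbon

The source may hold more compounds than are shown below. What is called first, only, known or untested is meant among the compounds shown, and "the series" means these compounds.

Compound 2 `COc1cc(Cl)cc(-c2nn(-c3cccc(NC(=O)Nc4ccc(Cl)c(C(F)(F)F)c4)c3)cc2-c2ccncc2)c1` was tested in a functional assay on DU-145 cells (Homo sapiens) for inhibition, read by sulforhodamine B assay, with a stated time of 48 h, tested at 0.01 uM (on this read-out lower numbers stand for a stronger effect and higher numbers for a weaker effect at the one concentration tested), where compound 2 gave 103%. Of the two numbers available, compound 2 stands lowest, but its nearest neighbour, compound 1 `O=C(Nc1cccc(-n2cc(-c3ccncc3)c(-c3cc(O)cc(Cl)c3)n2)c1)Nc1ccc(Cl)c(Cl)c1`, gave 108% in this assay, a value within the usual scatter of compound 2, so the two cannot be told apart. Compound 3 `COc1cc(Cl)cc(-c2nn(-c3cccc(NC(=O)Nc4ccc(Cl)c(Cl)c4)c3)cc2-c2ccncc2)c1` has not yet been measured in this assay. It differs from compound 2 in one place: chloro in place of trifluoromethyl on an aromatic carbon. Among the compounds with values here, no measured pair of compounds shows this change, so the expectation rests only on the two values in hand, which lie close together at the high end of the read-out. The expected step in this assay is a number 1 percentage points higher from compound 2 to compound 3 (within the scatter), none beyond the scatter. Compound 3 is therefore estimated at 104%, with a range from 90% to 118%.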

Compound 3, a percentage reported as activity, at one concentration (the size of the read-out at that concentration, not a potency): 101%
Compound 3: middle estimate off by 3 percentage points, on the high side; low and high end bracket the measured number.
By their numbers in this assay, from the lowest: compounds 3, 2 and 1 (each within the scatter of the next).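

In this assay, chloro in place of trifluoromethyl, which turns 4-chloro-3-(trifluoromethyl)phenyl into 3,4-dichlorophenyl, gives a number 2 percentage points lower from compound 2 to compound 3 (within the scatter), so this position takes either group with no difference that this read-out can separate. With 3,4-dichlorophenyl held constant, methyl in place of hydrogen on an oxygen on an aromatic ring gives a number 7 percentage points lower from compound 1 to compound 3 (within the scatter), so that change also stays inside the scatter. No independent measurement bears on these results.

All three compounds were read at a single concentration, so the compounds shown leave open whether either change would separate them at another concentration. They also leave open what a fluoro group, an amine or a carboxylic acid would give on this aromatic carbon.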